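The source may hold more compounds than are shown below. What is called first, only, known or untested is meant among the compounds shown, and "the series" means these compounds.

Compound 3 `Cc1ccc(-c2cc(NO)c(C(=O)Nc3ccccc3)c(=O)o2)cc1` is the starting point. In an ADME assay on Huh-7 cells (Homo sapiens) for cytotoxicity, read by a luciferase reporter and WST assay, with a stated time of 3 days (a lower number here means that less compound is tolerated, a higher number that more compound is tolerated), compound 3 gives only the limit of the assay, > 20000 nM, and no exact number; it is one of the readings described by the limit of > 20000 nM in this assay, at which 1 of the 3 values shown sits. Its two measured neighbours differ from it on an aromatic carbon: compound 1 `O=C(Nc1ccccc1)c1c(NO)cc(-c2ccc(F)cc2)oc1=O` gives 10300 nM, and compound 2 `O=C(Nc1ccccc1)c1c(NO)cc(-c2ccc(Cl)cc2)oc1=O` gives 11000 nM. The steps of an at least 1.9-fold higher number from compound 1 to compound 3 (0.28 log units; that floor lies within the scatter) and an at least 1.8-fold higher number from compound 2 to compound 3 (0.25 log units; that floor lies within the scatter) stay within the scatter, as does a 1.1-fold higher number from compound 1 to compound 2 (0.03 log units; within the scatter). Compound 4 `Cc1ccc(-c2cc(NO)c(C(=O)NCc3ccccc3)c(=O)o2)cc1` changes something else: benzyl in place of phenyl on an amide-type nitrogen. Within the data shown here, none of the measured steps touches the amide nitrogen, so they offer no direction for this change. A step that the limit leaves unreadable from compound 3 to compound 4 is therefore expected, nothing beyond the scatter. Compound 4 is expected to give about 25000 nM, between 12000 nM and 50000 nM, quite possibly again only a limit.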

Compound 4, half-maximal cytotoxic concentration: > 20000 nM
Compound 4: no number, only a limit; the forecaster's own chance of this, stated with the estimate: 65%; the middle value does not contradict the limit.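

Compound 3 and compound 4 both give only a limit, not a number, so no step can be read between them: the limit of > 20000 nM in this assay, at which 2 of the 4 values shown sit.

The compounds shown leave open whether benzyl in place of phenyl on the amide-type nitrogen changes the number at all.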